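This account rests on a few compounds, and the source may have more. Where it says the series, first, only, none or still open, it means among the compounds named here.

Compound 1 `Cc1cccc(-c2ccc(CCC(=O)N3CCCC3)cc2)c1` — 16500 nM
Compound 2 `CCCc1cccc(CCCCCCC(=O)N2CCCC2)c1` — > 100000 nM

Among the compounds with values here, in an assay on HEK293 cells for inhibition of N-acylethanolamine-hydrolyzing acid amidase (Rattus norvegicus), read by LC-MS, with a stated time of 30 min (a lower number here means a stronger inhibitor, a higher number a weaker inhibitor), compound 1 gives 16500 nM, the only true number among the values shown. Compound 2 gives > 100000 nM, which is a limit of the assay and not a number (the limit of > 100000 nM in this assay, at which 1 of the 2 values shown sits). Compound 3 `O=C(CCc1ccc(OC2CCCCC2)cc1)N1CCCC1` has not yet been measured; it differs from compound 1 by cyclohexyloxy in place of 3-methylphenyl on an aromatic carbon. Within the data shown here, no measured pair isolates this change, so only a small shift is expected, in this assay an estimated 1.5-fold higher number from compound 1 to compound 3 (0.18 log units; within the scatter), near the scatter and leaning toward weaker inhibition. Compound 3 is expected at 25000 nM, between 8000 nM and 80000 nM.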

Compound 3, half-maximal inhibitory concentration: 700 nM
Estimate against measurement, compound 3: 36-fold (1.55 log units) above, outside the stated range (below it).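

In this assay, this aromatic carbon proves sensitive to the group it carries: cyclohexyloxy in place of 3-methylphenyl gives a 24-fold lower number from compound 1 to compound 3 (1.37 log units; beyond the scatter). Both groups hold 7 heavy atoms, so the step comes with no change in that count, only with a non-aromatic ring and an oxygen replacing an aromatic ring. Nothing shown here explains why this swap has so large an effect. Still open, as far as these compounds go, is whether the oxygen or the non-aromatic ring carries the step; phenoxy or a directly attached cyclohexyl on the same carbon would separate the two.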